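Chain on the double-bonded nitrogen: hydroxyethyl to allyl

A few compounds are considered here, and "the series" means these few. Any claim that something is new, unique, unknown or untested is made for them only; others in the source may bear on it.

Measured so far:
Compound 1, `CC/N=c1/c(C#N)c2n(c(=O)n1-c1ccccc1)CCC2`: 30.4%
Compound 2, `N#Cc1c2n(c(=O)n(-c3ccccc3)/c1=N\CCO)CCC2`: 27.3%

In a functional assay on the whole organism (strain albino) for inhibition, with Rattus norvegicus as the target, read by paw edema, with a stated time of 4 h, at a dose of 0.029 mmol/kg by the oral route (on this read-out lower numbers stand for less inhibition and higher numbers for more inhibition at the one dose given (going by the name of the read-out)), compound 1 gives 30.4%, and in this assay compound 2 gives 27.3%. The two numbers lie within the scatter of each other; the one step recorded, a number 3.1 percentage points lower from compound 1 to compound 2 (within the scatter), is within the scatter, so compound 2 cannot be placed apart from compound 1 on the numbers shown.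

Compound 3, `C=CC/N=c1/c(C#N)c2n(c(=O)n1-c1ccccc1)CCC2`, differs from compound 2 by vinyl in place of hydroxymethyl on a saturated chain carbon bound to a double-bonded nitrogen. The measured step bears on the same chain: it introduced the hydroxy and, read backwards, shows its removal to be of no consequence beyond the scatter. Within the data shown here, no measured step covers the vinyl that enters, so nothing speaks for a shift in either direction.

For compound 3 a number near the two measured ones is expected, estimated at 30% with a range of 15% to 45%. The expected step is a number 2.7 percentage points higher from compound 2 to compound 3 (within the scatter), within the scatter.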

Compound 3, a percentage reported as inhibition, in the whole organism at one dose (the size of the read-out at that dose, not a potency): 14.3%
Compound 3: middle estimate off by 15.7 percentage points, on the high side; measured number outside the range, below it.
By their numbers in this assay, from the lowest: compound 3; then compounds 2 and 1 (each within the scatter of the next).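

In this assay the chain on the double-bonded nitrogen turns out not to be indifferent: vinyl in place of hydroxymethyl gives a number 13 percentage points lower from compound 2 to compound 3 (beyond the scatter), and vinyl in place of methyl gives a number 16.1 percentage points lower from compound 1 to compound 3 (beyond the scatter). The earlier step, a number 3.1 percentage points lower from compound 1 to compound 2 (within the scatter), showed only that adding the hydroxy left the number within the scatter, whereas the allyl chain of compound 3 stands apart from both other compounds. Nothing available accounts for this separation.

On these data alone, whether a saturated propyl chain would stay level with compound 1 and compound 2 or fall with compound 3 remains open, so the double bond and the chain itself cannot yet be told apart. Also open, as far as these compounds go, is how a longer chain or a terminal amine at this place would read at this one dose.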